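Extending a methyl to ethyl on the oxadiazole ring

The source may report more compounds than this note shows. Statements on the series, on what has been measured and on what is new or still open speak of the compounds shown alone.

Of the compounds shown here, two have been tested in a functional assay on RD cells (Homo sapiens) for inhibition, read by luminescence and ATP content, with a stated time of 72 h (on this read-out lower numbers stand for higher toxicity in this test and higher numbers for lower toxicity in this test), and both sit at limits rather than at numbers. Compound 1 `Cc1nc(-c2cnc3ccc(-c4ccc(O)cc4)cc3c2)no1` in this assay gives > 2500 nM, which is a limit of the assay. Compound 2 `COc1ccc(-c2ccc3ncc(-c4noc(C)n4)cc3c2)cc1` in this assay gives > 66700 nM, also a limit of the assay. Among the compounds with values here, the only measured step, a step that the two limits leave unreadable from compound 1 to compound 2, is therefore not readable, as the limit of > 2500 nM in this assay, at which 1 of the 2 values shown sits, and the limit of > 66700 nM in this assay, at which 1 of the 2 values shown sits, show: neither value is a number.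

Compound 3 `CCc1nc(-c2cnc3ccc(-c4ccc(OC)cc4)cc3c2)no1` differs from compound 2 by methyl in place of hydrogen on a saturated chain carbon bound to an aromatic carbon. Within the data shown here, no measured step bears on this kind of change, so there is no basis for expecting a shift beyond the usual scatter in this assay in either direction. Since compound 2 stands at a limit, compound 3 is expected to behave the same way and to show no measurable toxicity in this test.

Compound 3 in this assay is estimated at 66700 nM, with a range from 20000 nM to 200000 nM, and the step of a number no higher from compound 2 to compound 3 (the limit leaves the size open) is expected to be about nothing.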

Compound 3, half-maximal cytotoxic concentration: > 2500 nM
Compound 3 ended at the assay's limit; the forecaster's own chance of this, stated with the estimate: 85%; the middle value is on the limit's open side.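

The results for compound 2 and compound 3 in this assay are both limits of the assay rather than numbers, so the step between them cannot be read. The compounds shown leave open whether going from methyl to ethyl on the oxadiazole changes toxicity in this test, and at what concentration any of the three compounds would become toxic.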